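Compound 3: pyridin-2-yl on the shared core

A few compounds are considered here, and "the series" means these few. Any claim that something is new, unique, unknown or untested is made for them only; others in the source may bear on it.

In an ADME assay on MDBK cells (Bos taurus) for cytotoxicity, read by MTT assay, with a stated time of 96 h (on this read-out lower numbers stand for higher toxicity in this test and higher numbers for lower toxicity in this test), compound 1 `C/C(=N\NC(N)=S)c1ccc2c(c1)nc(-c1ccccc1)n2C1CCCCC1` gives 24000 nM. Compound 2 `COc1ccc(-c2nc3cc(/C(C)=N/NC(N)=S)ccc3n2C2CCCCC2)c(OC)c1` gives > 100000 nM, which is a limit of the assay and not a number. Compound 2 thus stands at the limit of > 100000 nM in this assay, at which 1 of the 2 values shown sits.

Compound 3 `C/C(=N\NC(N)=S)c1ccc2c(c1)nc(-c1ccccn1)n2C1CCCCC1` carries pyridin-2-yl in place of 2,4-dimethoxyphenyl on an aromatic carbon on an aromatic carbon between two ring nitrogen atoms. Going by the values given here, the one measured step at this place is an at least 4.1-fold higher number from compound 1 to compound 2 (0.61 log units; beyond the scatter), which lies beyond the scatter and is at least modest. As far as these compounds go, with the 2,4-dimethoxyphenyl group gone, a return towards compound 1 at 24000 nM is expected, which means a lower number in this assay, though the pyridin-2-yl group itself is untested. The expected change is an at least 3.3-fold lower number from compound 2 to compound 3 (0.52 log units; beyond the scatter). For compound 3 the estimate is 30000 nM, with an expected range of 10000 nM to 90000 nM.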

Compound 3, half-maximal cytotoxic concentration: 41000 nM
The estimate for compound 3 lay 1.4-fold (0.14 log units) below the measured number; measured number inside the range.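

In this assay, pyridin-2-yl in place of 2,4-dimethoxyphenyl gives an at least 2.4-fold lower number from compound 2 to compound 3 (0.38 log units; beyond the scatter), so a group at this position other than phenyl does not by itself carry the number to the level of compound 2. Pyridin-2-yl in place of phenyl gives a 1.7-fold higher number from compound 1 to compound 3 (0.23 log units; within the scatter), so the ring nitrogen of pyridin-2-yl cannot be told apart from the phenyl group in this test. Compound 2 remains a limit of the assay and not a number, so the full size of its steps stays unknown: the limit of > 100000 nM in this assay, at which 1 of the 3 values shown sits.

As far as these compounds go, whether one methoxy group alone, or an amine or a carboxylic acid on the aromatic ring at this position, would move the number remains open. Also open, from the compounds shown here alone, is how the number responds when an ethyl chain takes the place of the cyclohexyl group.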